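This account rests on a few compounds, and the source may have more. Where it says the series, first, only, none or still open, it means among the compounds named here.

Measured so far in a functional assay on HepG2 cells (Homo sapiens) for inhibition, read by MTT assay, with a stated time of 24 h; on this read-out lower numbers stand for stronger inhibition and higher numbers for weaker inhibition:
- compound 1 `CC1(C)[C@H]2CC[C@]1(C)N(Cc1cn(-c3ccccc3Br)nn1)C(=O)C2`: 150 nM
- compound 2 `CC1(C)[C@H]2CC[C@]1(C)N(Cc1cn(-c3ccccc3C#N)nn1)C(=O)C2`: 180 nM
- compound 3 `CC1(C)[C@H]2CC[C@]1(C)N(Cc1cn(-c3ccccc3Cl)nn1)C(=O)C2`: 60 nM

Compound 1 holds the second highest number of the three. Compound 2 lies within the scatter of it, the step being a 1.2-fold higher number from compound 1 to compound 2 (0.08 log units; within the scatter). Compound 3 sits apart, with a 2.5-fold lower number from compound 1 to compound 3 (0.40 log units; beyond the scatter), and from compound 2 the step to compound 3 is a 3.0-fold lower number from compound 2 to compound 3 (0.48 log units; beyond the scatter).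

Compound 4 `Cc1ccccc1-n1cc(CN2C(=O)C[C@@H]3CC[C@@]2(C)C3(C)C)nn1` differs from compound 1 by methyl in place of bromo on an aromatic carbon. For the measured compounds named here, no measured step swaps bromo for methyl at this position; the two steps that leave bromo, a 1.2-fold higher number from compound 1 to compound 2 (0.08 log units; within the scatter) and a 2.5-fold lower number from compound 1 to compound 3 (0.40 log units; beyond the scatter), are both modest and point in opposite directions. On that basis a step within or only just beyond the scatter is expected for compound 4, in this assay estimated as a 1.3-fold lower number from compound 1 to compound 4 (0.10 log units; within the scatter), giving an expected value of 120 nM with a range of 50 nM to 300 nM.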

Compound 4, half-maximal inhibitory concentration: 150 nM
Estimate against measurement, compound 4: 1.3-fold (0.10 log units) below; the measured number falls inside the stated range.
By their numbers in this assay, from the lowest: compound 3; then compounds 1, 4 and 2 (each within the scatter of the next).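

Methyl and bromo on this aromatic carbon read alike in this assay (no change at the digits printed from compound 1 to compound 4 (within the scatter)), and methyl and cyano also read alike (a 1.2-fold lower number from compound 2 to compound 4 (0.08 log units; within the scatter)). Chloro now stands apart from a third group (a 2.5-fold higher number from compound 3 to compound 4 (0.40 log units; beyond the scatter)), leaving compound 3 as the strongest of the four, with compounds 1, 2 and 4 within the scatter of one another. No measurement offers an explanation for this difference.

On these data alone, whether chloro's advantage is specific to that atom remains open, as a fluoro or methoxy group at this position would test this.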